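This account rests on a few compounds, and the source may have more. Where it says the series, first, only, none or still open, it means among the compounds named here.

Measured so far in a functional assay on HT-29 cells (Homo sapiens) for cytotoxicity, read by MTT assay, with a stated time of 24 h, tested at 1.6 ug/mL; on this read-out higher numbers stand for a stronger effect at the one concentration tested and lower numbers for a weaker effect:
- compound 1 `Cn1c(-c2ccc(NC(=O)CSc3nc4ccccc4o3)cc2)nc(-c2ccccc2)c1-c1ccccc1` gives 41%
- compound 2 `Cn1c(-c2ccc(NC(=O)CSc3nc4cc(Cl)ccc4o3)cc2)nc(-c2ccccc2)c1-c1ccccc1` gives 17.4%

Among the measured compounds shown here, compound 2 stands lowest of the two numbers; its nearest neighbour is compound 1, and the only step between measured compounds, a number 23.6 percentage points lower from compound 1 to compound 2 (beyond the scatter), is the one that separates them. For the measured compounds named here, that step is the sole piece of evidence for what happens on the same aromatic carbon of the fused system.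

Compound 3 `Cc1ccc2oc(SCC(=O)Nc3ccc(-c4nc(-c5ccccc5)c(-c5ccccc5)n4C)cc3)nc2c1` is not yet measured. It differs from compound 2 as follows: methyl in place of chloro on an aromatic carbon. Going by the values given here, no measured pair shows methyl against chloro at this carbon, so the direction can only be guessed from the fact that chloro cost compound 2 a modest loss relative to the unsubstituted compound 1. Methyl is expected to land between the two measured numbers rather than beyond them, so a small rise a number 8.6 percentage points higher from compound 2 to compound 3 (within the scatter) toward compound 1 is expected. For compound 3 the estimate in this assay is 26%, with a range from 10% to 45%.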

Compound 3, a percentage reported as activity, at one concentration (the size of the read-out at that concentration, not a potency): 15.5%
Beside the measured number, compound 3's estimate is 10.5 percentage points above it; the measured number falls inside the stated range.
By their numbers in this assay, from the lowest: compounds 3 and 2 (each within the scatter of the next); then compound 1.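

In this assay, methyl in place of chloro gives a number 1.9 percentage points lower from compound 2 to compound 3 (within the scatter), so the two groups cannot be told apart on this aromatic carbon. Methyl in place of hydrogen gives a number 25.5 percentage points lower from compound 1 to compound 3 (beyond the scatter), in the same direction as a number 23.6 percentage points lower from compound 1 to compound 2 (beyond the scatter), so within these three compounds the loss is not confined to chloro, and the unsubstituted compound 1 alone stands apart. No measurement is at hand that would account for this.

Still open, from the compounds shown here alone, is whether a methoxy group, an amine or a carboxylic acid on this carbon would give a number near that of compound 1 or near those of compound 2 and compound 3. Also open, going by these compounds, is whether chloro and methyl would behave alike on another carbon of the six-membered ring, and the single concentration gives no potency for any of the three.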